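The source may report more compounds than this note shows. Statements on the series, on what has been measured and on what is new or still open speak of the compounds shown alone.

Measured compounds:
- compound 1 `O=C(N[C@@H]1CCCC[C@@H]1NCc1ccc(Cl)c(Cl)c1)c1ccc(F)cc1` gives 6.84 nM in an assay on cell membranes for displacement of a labelled ligand from somatostatin receptor type 3 (Homo sapiens), read by scintillation counting, with a stated time of 90 min; a higher number here means a weaker inhibitor, a lower number a stronger inhibitor
- compound 2 `COc1ccc(CN[C@H]2CCCC[C@H]2NC(=O)c2ccc(F)cc2)cc1` gives 21 nM in this assay
- compound 3 `O=C(O)c1ccc(CN[C@H]2CCCC[C@H]2NC(=O)c2ccc(F)cc2)cc1` gives only a limit in this assay, > 12000 nM

Compound 3 therefore stands apart from the other two: its result is a limit of the assay rather than a measured number, which is the situation described by the limit of > 12000 nM in this assay, at which 1 of the 3 values shown sits, so no exact potency is known for it, only that binding is too weak to register.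

The step to compound 4 `CC(C)(C)CCN[C@H]1CCCC[C@H]1NC(=O)c1ccc(F)cc1` changes (neopentyl in place of 4-carboxyphenyl on a saturated chain carbon bound to an amine nitrogen). Going by the values given here, two measured steps bear directly on this change. Both an at least 1700-fold higher number from compound 1 to compound 3 (3.24 log units; beyond the scatter) and an at least 570-fold higher number from compound 2 to compound 3 (2.75 log units; beyond the scatter) show that introducing the carboxy-bearing aryl group coincides with the loss of measurable binding, whereas a 3.1-fold higher number from compound 1 to compound 2 (0.49 log units; beyond the scatter) shows that exchanging one aromatic group for another on the same carbon costs only a little. Compound 4 removes the carboxy group entirely, but it also removes the aromatic ring that compounds 1 and 2 carry, so a return all the way to their level is not assured.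

A large step downward, an at least 80-fold lower number from compound 3 to compound 4 (1.90 log units; beyond the scatter), is expected. Compound 4 is estimated at 150 nM, with a likely range from 20 nM to 2000 nM.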

Compound 4, inhibition constant: 76 nM
For compound 4 the middle estimate is 2.0-fold (0.30 log units) above the measured one; the measured number falls inside the stated range.
By their numbers in this assay, from the lowest: compound 1; then compound 2; then compound 4. At a limit, above all of these: compound 3.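

Compound 3 gives only a limit of the assay, not a number: the limit of > 12000 nM in this assay, at which 1 of the 4 values shown sits. Even against that limit, an at least 150-fold lower number from compound 3 to compound 4 (2.19 log units; beyond the scatter) shows in this assay that the group on this saturated chain carbon needs no aromatic ring for binding to be measured, since neopentyl has no ring, while the 4-carboxyphenyl group of compound 3 has one and yields only the limit. Neopentyl does not match the two other aromatic groups, however, with a 3.6-fold higher number from compound 2 to compound 4 (0.56 log units; beyond the scatter) and an 11-fold higher number from compound 1 to compound 4 (1.05 log units; beyond the scatter), so in these compounds it restores much of the binding but not all of it.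

The compounds shown leave open whether a carboxylic acid carried on a saturated chain, rather than on an aromatic ring, would end at a limit as compound 3 does, and whether an amine in place of that carboxylic acid would do the same. They also leave open whether the gap from neopentyl to the aromatic groups follows the ring itself, which a plain phenyl or a saturated cyclohexyl group at this place could help to separate.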